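Shortening the Chain Again: Hexyl to Propyl

The compounds below may be only part of what the source reports. "The series", "measured", "known", "first", "only" and "open" are said of these compounds alone.

Two measured compounds share one core and differ in the length of a chain. In a functional assay on DU-145 cells (Homo sapiens) for inhibition, read by MTT assay, with stated times of 18 h and 4 h (a higher number here means a weaker inhibitor, a lower number a stronger inhibitor), compound 1 `CCCCCCCCCCOP(=O)(O)OCCSC(=S)N1CCCCCC1` gives 24000 nM, while compound 2 `CCCCCCOP(=O)(O)OCCSC(=S)N1CCCCCC1` gives 77400 nM. That is the higher of the two numbers, which makes compound 2 the weaker inhibitor. The next structure is compound 3 `CCCOP(=O)(O)OCCSC(=S)N1CCCCCC1`, and the change is hydrogen in place of propyl on a saturated chain carbon, three bonds along the chain from an oxygen on an unsaturated carbon. Read one bond further out, this is hexyl to propyl. For the measured compounds named here, the only measured step that bears on it also shortens this chain: hydrogen in place of butyl gave a 3.2-fold higher number from compound 1 to compound 2 (0.51 log units; beyond the scatter), a modest step but beyond the scatter. A single step cannot establish a trend, but a further rise of similar or slightly smaller size is expected in this assay. The estimated step is a 2.3-fold higher number from compound 2 to compound 3 (0.37 log units; beyond the scatter). Compound 3 is expected at 180000 nM, with an estimated range of 90000 nM to 400000 nM.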

Compound 3, half-maximal inhibitory concentration: 86100 nM
Estimate against measurement, compound 3: 2.1-fold (0.32 log units) above; the whole stated range lies above it.
By their numbers in this assay, from the lowest: compound 1; then compounds 2 and 3 (each within the scatter of the next).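

In this assay, the change from hexyl to propyl gives little to read (a 1.1-fold higher number from compound 2 to compound 3 (0.05 log units; within the scatter)), so unlike the earlier shortening, this one does not separate its two compounds. Across the whole shortening, the result is still clear (a 3.6-fold higher number from compound 1 to compound 3 (0.55 log units; beyond the scatter)), which means the measurable difference among these three chains rests on compound 1, with its longer chain, while compounds 2 and 3 cannot be told apart. Nothing in the data shown accounts for this levelling off.

As far as these compounds go, it remains open whether a chain longer than that of compound 1 would lower the number further, and whether still shorter groups such as ethyl or methyl would stay level with compounds 2 and 3. Also open, from the compounds shown here alone, is what a chain ending in an amine or a carboxylic acid would give here.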